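The compounds below may be only part of what the source reports. "The series", "measured", "known", "first", "only" and "open" are said of these compounds alone.

In a functional assay for inhibition, with Rattus norvegicus as the target (a lower number here means a stronger inhibitor, a higher number a weaker inhibitor), compound 3 (`CC[C@H](C)/N=c1\c(O)c(O)\c1=N/Cc1ccc(C#N)cc1`) gives 2200 nM, the higher of the two values measured as actual numbers. Compound 1 (`C[C@@H](/N=c1\c(O)c(O)\c1=N/Cc1ccc(C#N)cc1)C(C)(C)C`) gives 270 nM, and the difference between them is an 8.1-fold higher number from compound 1 to compound 3 (0.91 log units; beyond the scatter). Compound 2 (`CCCC/N=c1\c(O)c(O)\c1=N/Cc1ccc(C#N)cc1`) gives > 30000 nM, which is a limit of the assay and not a number.

Compound 4 (`CCC/N=c1\c(O)c(O)\c1=N/Cc1ccc(C#N)cc1`) has not yet been measured. It differs as follows: hydrogen in place of methyl on a saturated chain carbon bound to a double-bonded nitrogen and a saturated chain carbon, so that sec-butyl becomes propyl. Going by the values given here, the closest precedent is the unbranched butyl chain of compound 2, and both steps that involve it are large: an at least 13-fold lower number from compound 2 to compound 3 (1.13 log units; beyond the scatter), and an at least 110-fold higher number from compound 1 to compound 2 (2.04 log units; beyond the scatter). A large step towards a higher number is therefore expected in this assay, possibly reaching the same limit. The expected change is an 11-fold higher number from compound 3 to compound 4 (1.06 log units; beyond the scatter). For compound 4 the estimated value is 25000 nM, with an expected range of 8000 nM to 60000 nM.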

Compound 4, half-maximal inhibitory concentration: 21900 nM
Compound 4: the middle estimate sits 1.1-fold (0.06 log units) above what was measured, and the stated range covers the measured number.
By their numbers in this assay, from the lowest: compound 1; then compound 3; then compound 4. At a limit, above all of these: compound 2.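

In this assay, the loss of this one methyl, which turns sec-butyl into propyl, gives a 10-fold higher number from compound 3 to compound 4 (1.00 log units; beyond the scatter), so the branch on the chain carbon bound to the double-bonded nitrogen matters in a pair differing only there. Propyl also gives the unbranched side of the series an actual number, and the full change from 1,2,2-trimethylpropyl to propyl reads as an 81-fold higher number from compound 1 to compound 4 (1.91 log units; beyond the scatter). Propyl and butyl cannot be put in order, since an at least 1.3-fold lower number from compound 2 to compound 4 (0.13 log units; that floor lies within the scatter) gives only a floor, and compound 2 stands at a limit and not at a number: the limit of > 30000 nM in this assay, at which 1 of the 4 values shown sits.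

The compounds shown leave open how a longer chain such as hexyl, or a ring such as cyclohexyl, would read on the double-bonded nitrogen. Going by these compounds alone, they also leave open how the mirror-image sec-butyl group would compare with the one in compound 3.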